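Ethyl to Isopropyl on the Urea Arm of Compound 3

This account rests on a few compounds, and the source may have more. Where it says the series, first, only, none or still open, it means among the compounds named here.

Measured compounds: compound 1 `CC(C)NC(=O)N1CCN(C(=S)SCc2cn(Cc3ccccc3F)nn2)CC1` gives 20800 nM in a functional assay on EC9706 cells (Homo sapiens) for cytotoxicity, read by MTT assay, with a stated time of 72 h; a higher number here means a weaker inhibitor, a lower number a stronger inhibitor; compound 2 `CC(C)NC(=O)N1CCN(C(=S)SCc2cn(Cc3ccc(Cl)cc3)nn2)CC1` gives 25600 nM; compound 3 `CCNC(=O)N1CCN(C(=S)SCc2cn(Cc3ccc(OC)cc3)nn2)CC1` gives > 128000 nM, which is a limit of the assay, not a number.

Compound 3 therefore stands only at the limit of > 128000 nM in this assay, at which 1 of the 3 values shown sits, and cannot be placed against the others. Compound 4 `COc1ccc(Cn2cc(CSC(=S)N3CCN(C(=O)NC(C)C)CC3)nn2)cc1` differs from it by methyl in place of hydrogen on a saturated chain carbon bound to an amide-type nitrogen and a saturated chain carbon, giving isopropylcarbamoyl, the group also present in compounds 1 and 2. For the measured compounds named here, the only measured step, a 1.2-fold higher number from compound 1 to compound 2 (0.09 log units; within the scatter), concerns a different part of the molecule and says nothing about this change. The two isopropylcarbamoyl compounds do give numbers, so a measurable value is expected, with the step estimated as an at least 2.8-fold lower number from compound 3 to compound 4 (0.45 log units; beyond the scatter). Compound 4 is expected at 45000 nM, within 15000 nM to 130000 nM.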

Compound 4, half-maximal inhibitory concentration: > 128000 nM
Compound 4: no number, only a limit; the forecaster's own chance of this, stated with the estimate: 40%; at least 2.8-fold (0.45 log units) between middle value and limit.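

The step from ethylcarbamoyl to isopropylcarbamoyl cannot be read, as both compounds stand at a limit of the assay: the limit of > 128000 nM in this assay, at which 2 of the 4 values shown sit. So isopropylcarbamoyl alone does not secure a measurable value, and the aromatic end also counts: methoxy in place of chloro on an aromatic carbon gives an at least 5.0-fold higher number from compound 2 to compound 4 (0.69 log units; beyond the scatter) in this series. Likewise, 4-methoxyphenyl in place of 2-fluorophenyl gives an at least 6.1-fold higher number from compound 1 to compound 4 (0.78 log units; beyond the scatter), a step beyond the scatter that the earlier pair did not show.

Still open, as far as these compounds go, is whether an amine or a hydroxy group in place of methoxy on that aromatic carbon would bring a measurable value. Also open, from the compounds shown here alone, is how ethylcarbamoyl behaves with chloro on that aromatic carbon.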